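Diethylamino to dipropylamino in the sulfone series

This account rests on a few compounds, and the source may have more. Where it says the series, first, only, none or still open, it means among the compounds named here.

Measured so far in a functional assay (aorta) with Rattus norvegicus as the target; on this read-out higher numbers stand for weaker inhibition and lower numbers for stronger inhibition:
- compound 1 `CCN(CC)CCCOc1ccc(S(=O)(=O)c2c(C)cn3ccccc23)cc1`: 3390 nM
- compound 2 `CCCCCCCCN(CCCCCCCC)CCCOc1ccc(S(=O)(=O)c2c(C(C)C)cn3ccccc23)cc1`: 30100 nM

Of these two numbers, compound 1 at 3390 nM has the lower, which means the stronger inhibition. Compound 2 stands at 30100 nM, and the gap between the two lies beyond the usual scatter of repeated measurements.

The next compound to be measured is compound 3 `CCCN(CCC)CCCOc1ccc(S(=O)(=O)c2c(C)cn3ccccc23)cc1`. It carries dipropylamino in place of diethylamino on a saturated chain carbon, three bonds along the chain from an oxygen on an aromatic ring. For the measured compounds named here, no pair of measured compounds differs in one place only, so the size of this step in this assay has no direct precedent. The change is modest, so a step within the scatter is expected, with a slight lean towards a higher number, given that compound 2 reads 30100 nM. The estimated step of a 1.2-fold higher number from compound 1 to compound 3 (0.07 log units; within the scatter) is therefore small. The expected value for compound 3 is 4000 nM, within an estimated range of 1400 nM to 11500 nM.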

Compound 3, half-maximal inhibitory concentration: 957 nM
Beside the measured number, compound 3's estimate is 4.2-fold (0.62 log units) above it; the whole stated range lies above it.
By their numbers in this assay, from the lowest: compound 3; then compound 1; then compound 2.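

In this assay, for the compounds shown here, the first single-place change gives a 3.5-fold lower number from compound 1 to compound 3 (0.55 log units; beyond the scatter) and so shows that, with the core of compound 1 held constant, the amine on a saturated chain carbon, three bonds along the chain from an oxygen on an aromatic ring, affects the read-out. Going by these compounds alone, the direction is towards stronger inhibition with dipropylamino in place of diethylamino, and the step lies beyond the usual scatter, even though the change adds only two carbons to the group, as the heavy-atom counts show. Within the data shown here, nothing measured so far accounts for this gain, so no cause can be assigned to it.

Compound 2 differs from compound 1 in two places, so it cannot show how the read-out follows the length of the amine chains alone, and the dioctylamino group cannot be judged separately from the isopropyl group on the core. Going by these compounds, whether dibutylamino extends the step seen with dipropylamino, and whether a ring amine such as piperidine keeps it, remains open.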